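From aromatic ring to open chain: compound 4

The compounds below may be only part of what the source reports. "The series", "measured", "known", "first", "only" and "open" are said of these compounds alone.

Measured so far in a functional assay on MCF7 cells (Homo sapiens) for antiproliferative activity, read by CCK-8 assay, with a stated time of 72 h; on this read-out lower numbers stand for stronger inhibition and higher numbers for weaker inhibition:
- Compound 1 `CCOc1cc(C(C)(C)C)ccc1C1=NC(c2ccc(Cl)cc2)C(c2ccc(Cl)cc2)N1C(=O)N1CCN(CCCCCC(=O)NO)CC1` gives 7260 nM
- Compound 2 `CCOc1cc(C(C)(C)C)ccc1C1=NC(c2ccc(Cl)cc2)C(c2ccc(Cl)cc2)N1C(=O)N1CCN(Cc2ccc(C(=O)NO)cc2)CC1` gives 3970 nM
- Compound 3 `CCOc1cc(C(C)(C)C)ccc1C1=NC(c2ccc(Cl)cc2)C(c2ccc(Cl)cc2)N1C(=O)N1CCN(c2ncc(C(=O)NO)cn2)CC1` gives 3460 nM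

Compound 3 stands at the low end of these numbers, level with its nearest neighbour (a 1.1-fold lower number from compound 2 to compound 3 (0.06 log units; within the scatter)). Its gap to the open-chain compound is modest but passes the scatter (a 2.1-fold lower number from compound 1 to compound 3 (0.32 log units; beyond the scatter)). The other step from that chain stays within the scatter (a 1.8-fold lower number from compound 1 to compound 2 (0.26 log units; within the scatter)).

The unmeasured compound 4 `CCOc1cc(C(C)(C)C)ccc1C1=NC(c2ccc(Cl)cc2)C(c2ccc(Cl)cc2)N1C(=O)N1CCN(CCCCCCCC(=O)NO)CC1` carries 7-(hydroxycarbamoyl)heptyl in place of 5-(hydroxycarbamoyl)pyrimidin-2-yl on an amine nitrogen in a ring. Within the data shown here, this runs roughly opposite to the modest step, so the closest guide is compound 1 at 7260 nM, the only measured compound with an open chain. Among the measured compounds shown here, no measured pair shows what the heptyl chain does compared with the pentyl chain. A small rise in this assay is therefore expected, close to the scatter, as the estimated 1.7-fold higher number from compound 3 to compound 4 (0.24 log units; within the scatter) shows. For compound 4 the estimate is 6000 nM, with an expected range from 2800 nM to 13000 nM.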

Compound 4, half-maximal inhibitory concentration: 4830 nM
Compound 4: the middle estimate sits 1.2-fold (0.09 log units) above what was measured, and the stated range covers the measured number.
By their numbers in this assay, from the lowest: compounds 3, 2, 4 and 1 (each within the scatter of the next, the first and the last beyond it).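

Placing 7-(hydroxycarbamoyl)heptyl on the amine nitrogen in the ring, where compound 3 has an aromatic ring, gives no separation that can be read in this assay (a 1.4-fold higher number from compound 3 to compound 4 (0.14 log units; within the scatter)). Compound 4 also stays within the scatter of the two other compounds, both against the benzyl-linked group (a 1.2-fold higher number from compound 2 to compound 4 (0.09 log units; within the scatter)) and against the shorter open chain (a 1.5-fold lower number from compound 1 to compound 4 (0.18 log units; within the scatter)), so this open chain joins the aromatic linkers in one band of numbers, and extending the chain shows no readable effect. Nothing measured here explains these numbers.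

Every compound shown carries the hydroxycarbamoyl group, so its own contribution remains open, and a carboxylic acid at the same chain end would address that. Also open, going by these compounds, is how a much shorter chain on the same nitrogen would behave in this cell assay.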